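Dropping the chloro from compound 2

This account rests on a few compounds, and the source may have more. Where it says the series, first, only, none or still open, it means among the compounds named here.

Compound 1 `COc1ccc(CSc2nnc(-c3cc([N+](=O)[O-])cc(C(F)(F)F)c3)n2Cc2ccccc2)cc1` is one of two measured members of this small set. In an ADME assay on HepG2 cells (Homo sapiens) for cytotoxicity, with a stated time of 48 h (on this read-out lower numbers stand for stronger inhibition and higher numbers for weaker inhibition), compound 1 gives > 30000 nM, which is a limit of the assay rather than a number. Compound 2 `O=[N+]([O-])c1cc(-c2nnc(SCc3ccc(Cl)cc3)n2Cc2ccccc2)cc(C(F)(F)F)c1` gives > 30000 nM in this assay, again only a limit. The step that the two limits leave unreadable from compound 1 to compound 2 therefore cannot be sized, because of the limit of > 30000 nM in this assay, at which 2 of the 2 values shown sit. Compound 3 `O=[N+]([O-])c1cc(-c2nnc(SCc3ccccc3)n2Cc2ccccc2)cc(C(F)(F)F)c1` differs from compound 2 by hydrogen in place of chloro on an aromatic carbon. Among the measured compounds shown here, no measured step bears on a change of this kind, and compound 2 itself stands only at a limit. Compound 3 is expected at 40000 nM, within 15000 nM to 150000 nM, a step that the limit leaves unreadable from compound 2 to compound 3.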

Compound 3, half-maximal inhibitory concentration: 21500 nM
The estimate for compound 3 lay 1.9-fold (0.27 log units) above the measured number, and the stated range covers the measured number.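

Among the compounds shown here, with hydrogen on this aromatic carbon, compound 3 gives the first real number in this assay, 21500 nM, so this position can now be read on at least one side. Hydrogen in place of chloro gives an at least 1.3-fold lower number from compound 2 to compound 3 (0.14 log units; that floor lies within the scatter), and hydrogen in place of methoxy gives an at least 1.3-fold lower number from compound 1 to compound 3 (0.14 log units; that floor lies within the scatter). Both steps are only floors, and their true size stays unknown: the limit of > 30000 nM in this assay, at which 2 of the 3 values shown sit.

The step between compound 1 and compound 2 still cannot be read. From the compounds shown here alone, whether a fluoro, a methyl or a hydroxyl group on this carbon would give a number rather than a limit remains open.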